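A five-membered aromatic ring enters at the amine nitrogen

The compounds below may be only part of what the source reports. "The series", "measured", "known", "first", "only" and "open" are said of these compounds alone.

In a functional assay on A-431 cells (Homo sapiens) for inhibition, read by sulforhodamine B assay, with a stated time of 2 days (on this read-out higher numbers stand for weaker inhibition of growth and lower numbers for stronger inhibition of growth), compound 2 `CC1=C(C(=O)Nc2cccc([N+](=O)[O-])c2)C(c2ccc(O)cc2O)NC(NN)=N1` gives 24300 nM and compound 1 `CC1=C(C(=O)Nc2cccc([N+](=O)[O-])c2)C(c2ccc(O)cc2O)NC(NCc2ccccc2)=N1` gives 35600 nM with the two values lying within the scatter of each other. Compound 3 `CC1=C(C(=O)Nc2cccc([N+](=O)[O-])c2)C(c2ccc(O)cc2O)NC(N/N=C/c2cccs2)=N1` has not yet been measured. Its difference from compound 2 is a group of 7 heavy atoms (5 carbon, 1 nitrogen, 1 sulfur; one five-membered aromatic ring with 1 hetero atom) in place of one nitrogen atom, on an amine nitrogen on the amine nitrogen whose other neighbour is a carbon with a double bond to nitrogen. Going by the values given here, the only measured step at this nitrogen, amino in place of benzyl (a 1.5-fold lower number from compound 1 to compound 2 (0.17 log units; within the scatter)), stays within the scatter, so no step beyond the scatter is expected in this assay for compound 3, although neither measured compound carries the entering ring. The estimated step (a 1.1-fold lower number from compound 2 to compound 3 (0.04 log units; within the scatter)) is accordingly small. Compound 3 is expected at about 22000 nM with an estimated range from 7000 nM to 60000 nM on this evidence.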

Compound 3, concentration for 50% growth inhibition: 19100 nM
Estimate against measurement, compound 3: 1.2-fold (0.06 log units) above, and the stated range covers the measured number.
By their numbers in this assay, from the lowest: compounds 3, 2 and 1 (each within the scatter of the next).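

In this assay, the group carrying a five-membered aromatic ring with 1 hetero atom, placed on the amine nitrogen, stays within the scatter of the amino group (a 1.3-fold lower number from compound 2 to compound 3 (0.10 log units; within the scatter)) and of the benzyl group (a 1.9-fold lower number from compound 1 to compound 3 (0.27 log units; within the scatter)). Across compounds 1, 2 and 3, this nitrogen has now held a six-membered aromatic ring of carbon only, a five-membered aromatic ring and no ring at all, with no step beyond the scatter, so the entering ring and its double bond bring no separable difference on this read-out. No measurement at hand offers an explanation for this lack of separation.

The compounds shown leave open whether any group on this nitrogen, such as a carboxylic acid, a basic amine or a longer alkyl chain, would give a step beyond the scatter. All three also share the rest of the core, so they do not show whether the same lack of separation would hold with a different group elsewhere on it.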